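The compounds below may be only part of what the source reports. "The series", "measured", "known", "first", "only" and "open" are said of these compounds alone.

In a functional assay on MCF7 cells (Homo sapiens) for antiproliferative activity, read by MTT assay, with a stated time of 72 h (on this read-out higher numbers stand for weaker inhibition and lower numbers for stronger inhibition), compound 1 `CCCSc1nc(N/N=C/c2cccnc2)c2nnn(Cc3ccccc3)c2n1`, which carries pyridin-3-yl, gives 58700 nM. Compound 2 `CCCSc1nc(N/N=C/c2ccccc2Cl)c2nnn(Cc3ccccc3)c2n1` gives 13800 nM, and compound 3 `C#CCSc1nc(N/N=C/c2cc(OC)c(OC)c(OC)c2)c2nnn(Cc3ccccc3)c2n1` gives 17000 nM, so these two sit level within the usual scatter, and both stand clearly apart from compound 1. The next structure is compound 4 `CCCSc1nc(N/N=C/c2cccs2)c2nnn(Cc3ccccc3)c2n1`, which has thiophen-2-yl in place of the 2-chlorophenyl of compound 2 on a carbon with a double bond to nitrogen: thiophen-2-yl in place of 2-chlorophenyl on a carbon with a double bond to nitrogen.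

Among the measured compounds shown here, only one measured step changes this same place, a 4.3-fold lower number from compound 1 to compound 2 (0.63 log units; beyond the scatter), and it is modest but beyond the scatter. Compound 3 differs from compound 2 in more than one place, so it offers no clean guide. Thiophen-2-yl is an aromatic ring with a hetero atom, like the pyridin-3-yl of compound 1 at 58700 nM, so part of that step may be undone. A small move toward a higher number is therefore expected in this assay, probably no larger than the scatter. The expected step is a 1.6-fold higher number from compound 2 to compound 4 (0.20 log units; within the scatter). For compound 4 the estimated value is 22000 nM, with an expected range from 9000 nM to 55000 nM.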

Compound 4, half-maximal inhibitory concentration: > 64000 nM
Compound 4 gave a limit, no number; the forecaster's own chance of this, stated with the estimate: 5%; middle value at least 2.9-fold (0.46 log units) from the limit.
By their numbers in this assay, from the lowest: compounds 2 and 3 (each within the scatter of the next); then compound 1. At a limit, above all of these: compound 4.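

Thiophen-2-yl in place of 2-chlorophenyl on a carbon with a double bond to nitrogen gives an at least 4.6-fold higher number from compound 2 to compound 4 (0.66 log units; beyond the scatter), a step that is at least modest. Together with a 4.3-fold lower number from compound 1 to compound 2 (0.63 log units; beyond the scatter), this means that among compounds 1, 2 and 4, the two with a hetero atom in the ring, pyridin-3-yl and thiophen-2-yl, both sit clearly higher than the 2-chlorophenyl of compound 2, so the lower number here goes with 2-chlorophenyl. In this assay compound 4 gives only a limit, not a number: the limit of > 64000 nM in this assay, at which 1 of the 4 values shown sits.

Thiophen-2-yl in place of pyridin-3-yl gives an at least 1.0-fold higher number from compound 1 to compound 4 (0.03 log units; that floor lies within the scatter); that floor lies within the scatter, so these two rings cannot be ranked. A plain phenyl ring would separate the part played by the chlorine from that of the carbon-only ring, and a phenyl ring carrying an amine would test how much else this place accepts.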